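Swapping the phenyl on the sulfonyl for a fused bicyclic group

The source may hold more compounds than are shown below. What is called first, only, known or untested is meant among the compounds shown, and "the series" means these compounds.

Compounds measured so far:
- compound 1, `O=S(=O)(c1ccccc1)c1cn(C2CCCNC2)c2ncccc12`, 47 nM
- compound 2, `O=S(=O)(c1cccc(Br)c1)c1cn(C2CCCNC2)c2ncccc12`, 72 nM
- compound 3, `O=S(=O)(c1cccc(F)c1)c1cn(C2CCCNC2)c2ncccc12`, 67 nM

All three share one core and differ only in the ring attached to the sulfonyl sulfur. In a functional assay on HeLa cells for agonist activity at 5-hydroxytryptamine receptor 6 (Homo sapiens), read by cAMP accumulation and immunoassay (a lower number here means that less compound is needed, a higher number that more compound is needed for the effect), compound 3 gives 67 nM, the second highest of the three numbers; its nearest neighbour is compound 2 and its furthest is compound 1, and both gaps fall within the scatter. The steps seen so far are all small: a 1.5-fold higher number from compound 1 to compound 2 (0.19 log units; within the scatter), a 1.4-fold higher number from compound 1 to compound 3 (0.15 log units; within the scatter) and a 1.1-fold lower number from compound 2 to compound 3 (0.03 log units; within the scatter).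

Compound 4, `O=S(=O)(C1=C(Cl)NC2SC=CN12)c1cn(C2CCCNC2)c2ncccc12`, is not yet measured. Relative to compound 3 the change is a group of 9 heavy atoms (5 carbon, 2 nitrogen, 1 sulfur, 1 chlorine; 2 five-membered non-aromatic rings with 2 hetero atoms each) in place of a group of 7 heavy atoms (6 carbon, 1 fluorine; one six-membered aromatic ring of carbon only), on a sulfonyl sulfur. This is a different kind of change from those measured: the three steps above only exchange a single atom on an aromatic ring that stays in place, whereas here the whole aromatic ring leaves and two fused non-aromatic rings enter. Those steps therefore bear on compound 4 only loosely; they show that small changes on the ring were tolerated, not what happens when the ring itself is replaced.

Given that, the expectation for compound 4 in this assay is a moderately higher number, a 3.0-fold higher number from compound 3 to compound 4 (0.47 log units; beyond the scatter), with wide uncertainty; the estimate for compound 4 is 200 nM, between 40 nM and 1200 nM.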

Compound 4, half-maximal effective concentration: 66 nM
For compound 4 the middle estimate is 3.0-fold (0.48 log units) above the measured one, and the stated range covers the measured number.
By their numbers in this assay, from the lowest: compounds 1, 4, 3 and 2 (each within the scatter of the next).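

In this assay, the whole 3-fluorophenyl on the sulfonyl sulfur gives way to a larger group of two five-membered non-aromatic rings, and every step to the new compound stays within the scatter (a 1.0-fold lower number from compound 3 to compound 4 (0.01 log units; within the scatter); a 1.1-fold lower number from compound 2 to compound 4 (0.04 log units; within the scatter); a 1.4-fold higher number from compound 1 to compound 4 (0.15 log units; within the scatter)). The earlier compounds shown here exchanged only a single atom on an aromatic ring that stayed in place, whereas this result shows that, at this position, the six-membered aromatic ring of carbon only can be absent without a readable difference, even though the entering group brings nitrogen, sulfur, chlorine and hydrogen-bond donor and acceptor atoms that the leaving ring lacks. Nothing available here accounts for this result.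

The new group differs from the phenyl rings in many atoms at once, so these compounds cannot show which of its parts, such as the chlorine or the sulfur, matters for the number in this assay. Also open, on these data alone, is how a carboxylic acid, a primary amine or a plain cyclohexyl ring on the sulfonyl sulfur would compare.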